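A few compounds are considered here, and "the series" means these few. Any claim that something is new, unique, unknown or untested is made for them only; others in the source may bear on it.

Measured so far in a functional assay on the whole organism for positive allosteric modulation, with Rattus norvegicus as the target; on this read-out higher numbers stand for an effect only at larger amounts of compound and lower numbers for an effect already at smaller amounts:

compound 1: `Cc1nn(C)c2c1C(c1cccc(Cl)c1)=NCCN2` — 0.63 mg/kg
compound 2: `CC(=O)N1CCN=C(c2cccc(Cl)c2)c2c(C)nn(C)c21` — the value of compound 2 is a limit of the assay, > 10 mg/kg the limit of > 10 mg/kg in this assay, at which 1 of the 3 values shown sits.
compound 3: `Cc1nn(C)c2c1C(c1cccc(Cl)c1C)=NCCN2` — 1.25 mg/kg

Compound 1 holds the lowest of the two numbers given in this assay; compound 3 is its nearest neighbour, and the two lie within the scatter of each other. Two steps from compound 1 are known. Replacing a hydrogen on a nitrogen in the shared core by acetyl gives an at least 15-fold higher number from compound 1 to compound 2 (1.20 log units; beyond the scatter), a large move to a limit. Adding a methyl on an aromatic carbon of the six-membered aromatic ring gives a 2.0-fold higher number from compound 1 to compound 3 (0.30 log units; within the scatter), which is within the scatter.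

The compound not yet measured is compound 4, `Cc1nn(C)c2c1C(c1cccc(C#N)c1)=NCCN2`. It differs from compound 1 as follows: cyano in place of chloro on an aromatic carbon. Going by the values given here, of the known steps only the one from compound 1 to compound 3 touches the same six-membered aromatic ring, and that step was within the scatter; the step to compound 2 sits at another place and does not bear on this change. No step beyond the scatter is therefore expected for the exchange of chloro for cyano. Compound 4 is estimated at 0.8 mg/kg, with a range of 0.3 mg/kg to 2.5 mg/kg, that is an expected step of a 1.3-fold higher number from compound 1 to compound 4 (0.10 log units; within the scatter).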

Compound 4, minimum effective dose: 1.25 mg/kg
For compound 4 the middle estimate is 1.6-fold (0.19 log units) below the measured one; low and high end bracket the measured number.
By their numbers in this assay, from the lowest: compounds 1, 3 and 4 (each within the scatter of the next). At a limit, above all of these: compound 2.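

In this assay, cyano in place of chloro on an aromatic carbon, meta to a large group, gives a 2.0-fold higher number from compound 1 to compound 4 (0.30 log units; within the scatter). Going by these compounds alone, this place on the six-membered aromatic ring therefore takes a cyano group, with its triple bond and a hydrogen-bond acceptor that chloro lacks, without a step beyond the scatter; the earlier compounds showed only a methyl added to this ring, with the chloro left in place. No measurement shown bears on the reason for this result.

Still open, going by these compounds, is whether this place stays as undemanding with a methoxy group, an amine or a carboxylic acid, or with hydrogen alone in place of the chloro. Also open, on these data alone, is how cyano behaves alongside the added methyl of compound 3.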